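A Furanylmethyl Amine on the Thienopyrimidine Series

The source may hold more compounds than are shown below. What is called first, only, known or untested is meant among the compounds shown, and "the series" means these compounds.

The study measures nitrite suppression in liver cells, read in a functional assay on L02 cells (Homo sapiens) for inhibition, read by Griess assay, with stated times of 1 h and 24 h; on this read-out lower numbers stand for stronger inhibition and higher numbers for weaker inhibition. Within the data shown here, compound 1 `CCCc1nn(C)c2c(NC3CC3)nc(/C=C/c3nc(C)c(C)nc3C)nc12` is the only member of the set with a number rather than a limit: in this assay compound 1 gives 706000 nM, a weak result. Compound 2 `CC(C)c1ccc(Nc2nc(/C=C/c3ccco3)nc3ccsc23)cc1` reaches only the limit of this assay, and compound 2 is recorded as > 1000000 nM. Compound 3 `CNc1nc(/C=C/c2cc(OC)c(OC)c(OC)c2)nc2ccsc12` likewise sits at the limit, with compound 3 recorded as > 1000000 nM. Two of the three values shown therefore stand at the limit of > 1000000 nM in this assay, at which 2 of the 3 values shown sit, and compound 3 stands among them, so no finer placing of compound 3 on the scale is possible.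

Compound 4 `COc1cc(/C=C/c2nc(NCc3ccco3)c3sccc3n2)cc(OC)c1OC` differs from compound 3 in one place: furan-2-yl in place of hydrogen on a saturated chain carbon bound to a nitrogen on an aromatic ring. Among the measured compounds shown here, no measured pair in this set shows what such a change does, so no direction can be read from data. Given that compound 3 sits at the limit in this assay, the author expects the step of an at least 1.1-fold lower number from compound 3 to compound 4 (0.04 log units; that floor lies within the scatter) to be no larger than the scatter, and most likely compound 4 will again return only a limit. The estimate for compound 4 in this assay is 900000 nM, within a range from 350000 nM to 3000000 nM.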

Compound 4, half-maximal inhibitory concentration: 189000 nM
For compound 4 the middle estimate is 4.8-fold (0.68 log units) above the measured one; the whole stated range lies above it.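

In this assay, among these compounds, furan-2-yl in place of hydrogen on a saturated chain carbon bound to a nitrogen on an aromatic ring gives an at least 5.2-fold lower number from compound 3 to compound 4 (0.72 log units; beyond the scatter), the only step in this set that can be read at this place. It shows that this position is not silent: the change from methylamino to ((furan-2-yl)methyl)amino turns a compound recorded only as a limit into one with a measured number, which neither the limit of compound 3 nor the different structures of compound 1 and compound 2 could show. The step is a floor and not a full size because compound 3 is recorded only as a limit of the assay, so the real gap may be wider: the limit of > 1000000 nM in this assay, at which 2 of the 4 values shown sit.

What the compounds shown leave open is whether the furan ring itself carries this gain, or whether a phenyl ring, a thiophene or a longer chain such as butyl at the same place would do as much. With a single step, they also leave open whether the same change would have a like result on the core of compound 1 or with the other groups carried by compound 2.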